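The source may hold more compounds than are shown below. What is called first, only, known or untested is meant among the compounds shown, and "the series" means these compounds.

The measured compounds:

- compound 1, `C[C@H](NC(=O)Nc1cccc(F)c1)c1ccccc1`: 97% in an ADME assay on the whole organism with Oryza sativa as the target, tested at 0.1 uM; a higher number here means a weaker effect of the compound at the concentration tested, a lower number a stronger effect
- compound 2, `C[C@H](NC(=O)Nc1cccc(F)c1F)c1ccccc1`: 100% in this assay

In this assay compound 2 gives 100% and compound 1 gives 97%, so compound 2 stands at the top of this pair of numbers, but the step of a number 3 percentage points higher from compound 1 to compound 2 (within the scatter) lies within the scatter, and the two compounds cannot be told apart on this read-out. Compound 3, `C[C@H](NC(=O)Nc1cccc(C(F)(F)F)c1F)c1ccccc1`, differs from compound 2 by trifluoromethyl in place of fluoro on an aromatic carbon.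

For the measured compounds named here, only one measured step exists, a number 3 percentage points higher from compound 1 to compound 2 (within the scatter), and it concerns a different change on the same ring, a fluoro in place of hydrogen; it was within the scatter. Going by the values given here, that step bears on the present one only loosely, as no compound carrying a trifluoromethyl has been measured. With the two measured numbers both close to the top of the scale, the step from compound 2 to compound 3 is expected to stay within the scatter in this assay, with no clear direction.

Compound 3 is therefore estimated at 97%, with a range from 85% to 100%. This estimate implies an expected step of a number 3 percentage points lower from compound 2 to compound 3 (within the scatter) that remains within the scatter.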

Compound 3, a percentage reported as activity, at one concentration (the size of the read-out at that concentration, not a potency): 99%
For compound 3 the middle estimate is 2 percentage points below the measured one; the range from low to high includes it.
By their numbers in this assay, from the lowest: compounds 1, 3 and 2 (each within the scatter of the next).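

In this assay, trifluoromethyl in place of fluoro, on an aromatic carbon ortho to a fluoro group and meta to a large group, gives a number 1 percentage points lower from compound 2 to compound 3 (within the scatter). This position therefore takes a group of 4 heavy atoms where there was a group of 1 heavy atom, and the read-out still cannot tell the two compounds apart, something the earlier step, a number 3 percentage points higher from compound 1 to compound 2 (within the scatter), a fluoro in place of hydrogen on the same ring, could not show. No measurement given here bears on why this change leaves the read-out unresolved.

Going by these compounds, what stays open is whether any other kind of group at this position, such as an amine, a carboxylic acid or a nitrile, would give a number that stands clear of the scatter in this assay. On these data alone, it is equally open whether a longer chain or another change elsewhere on the shared core would separate compounds that this substitution on the ring has so far left indistinguishable.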